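This account rests on a few compounds, and the source may have more. Where it says the series, first, only, none or still open, it means among the compounds named here.

Working notes on the series. Compound 2 `CCOC(=O)Nc1ccc(S(=O)(=O)N2C[C@H](c3ccccc3)NC2=O)cc1C` is the point of reference: in a functional assay on HCT-116 cells (Homo sapiens) for cytotoxicity, read by MTT assay (a lower number here means a stronger inhibitor, a higher number a weaker inhibitor), compound 2 gives 70 nM, the lowest of the three numbers in hand. Compound 1 `CCCCOC(=O)Nc1ccc(S(=O)(=O)N2C[C@H](c3ccccc3)NC2=O)cc1CC` gives 200 nM and compound 3 `CCOC(=O)Nc1ccc(S(=O)(=O)N2C[C@H](c3ccccc3)NC2=O)cc1Cl` gives 200 nM. Going by the values given here, the only one-place step measured is a 2.9-fold higher number from compound 2 to compound 3 (0.46 log units; beyond the scatter). Compound 4 `CCOC(=O)Nc1ccc(S(=O)(=O)N2C[C@H](c3ccccc3)NC2=O)c(C)c1C` differs from compound 2 by methyl in place of hydrogen on an aromatic carbon, the entering group sitting ortho to a large group, ortho to a methyl group and meta to the (ethoxycarbonyl)amino group. Among the compounds with values here, no measured step adds a methyl; the methyl-to-chloro step bears on this change only loosely, showing that a small change at the ring can move the number modestly. A step of a 1.6-fold higher number from compound 2 to compound 4 (0.20 log units; within the scatter) is expected, possibly within the scatter. Compound 4 is therefore estimated at 110 nM, between 40 nM and 300 nM.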

Compound 4, half-maximal inhibitory concentration: 350 nM
For compound 4 the middle estimate is 3.2-fold (0.50 log units) below the measured one; measured number outside the range, above it.
By their numbers in this assay, from the lowest: compound 2; then compounds 1, 3 and 4 (each within the scatter of the next).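

Adding methyl on this aromatic carbon, ortho to a large group and ortho to a methyl group, gives a 5.0-fold higher number from compound 2 to compound 4 (0.70 log units; beyond the scatter) in this assay. Going by these compounds alone, this is the first measured step at this carbon and the first that adds a group rather than exchanging one, and it shows that one added methyl here is enough to move the number beyond the scatter. No measurement in hand bears on the reason for this step.

Going by these compounds, whether fluoro, methoxy or an amine on the same carbon would raise the number as methyl does remains open. Also open, on these data alone, is whether the step from compound 2 to compound 4 would carry over to a core with chloro in place of the existing methyl.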